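Homologating the hydroxyalkyl amine tail: compound 3 to compound 4

The compounds below may be only part of what the source reports. "The series", "measured", "known", "first", "only" and "open" are said of these compounds alone.

Three members of the series have been read in an ADME assay on A549 cells (Homo sapiens) for cytotoxicity, read by CellTiter-Glo; on this read-out lower numbers stand for higher toxicity in this test and higher numbers for lower toxicity in this test. Compound 1 `Cc1c(Cc2ccccc2)c(=O)oc2cc(OCC(O)CNc3ccccc3)ccc12` carries a phenyl on the amine nitrogen; in this assay compound 1 reaches only a limit of the assay, > 100000 nM. Compound 2 `Cc1c(Cc2ccccc2)c(=O)oc2cc(OCC(O)CNc3cc([N+](=O)[O-])ccc3O)ccc12` likewise gives only a limit, > 100000 nM. Within the data shown here, compound 3 `Cc1c(Cc2ccccc2)c(=O)oc2cc(OCC(O)CNCCCO)ccc12`, with 3-hydroxypropyl on that nitrogen, is the only member with a number: 53400 nM. The step that the two limits leave unreadable from compound 1 to compound 2 stays unreadable, since (the limit of > 100000 nM in this assay, at which 2 of the 3 values shown sit). The steps of an at least 1.8-fold lower number from compound 1 to compound 3 (0.27 log units; that floor lies within the scatter) and an at least 1.8-fold lower number from compound 2 to compound 3 (0.27 log units; that floor lies within the scatter) are therefore floors only, and each floor lies within the scatter.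

Compound 4 `Cc1c(Cc2ccccc2)c(=O)oc2cc(OCC(O)CNCCCCCCO)ccc12` lengthens the tail: 3-hydroxypropyl in place of hydroxy on a saturated chain carbon, three bonds along the chain from an amine nitrogen. Among the measured compounds shown here, no measured step alters a saturated chain in this way; the two readable steps concern the group on the amine nitrogen and are in any case bounded within the scatter. Expected, then, is a step of a 1.1-fold lower number from compound 3 to compound 4 (0.03 log units; within the scatter) that stays within the scatter. The estimate for compound 4 is 50000 nM, with a range from 20000 nM to 120000 nM.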

Compound 4, half-maximal cytotoxic concentration: 40300 nM
The estimate for compound 4 lay 1.2-fold (0.09 log units) above the measured number; low and high end bracket the measured number.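

In this assay, the change from hydroxy to 3-hydroxypropyl on a saturated chain carbon, three bonds along the chain from an amine nitrogen, gives a 1.3-fold lower number from compound 3 to compound 4 (0.12 log units; within the scatter), so this longer tail leaves the read-out unchanged within the scatter. Among these compounds, what the earlier steps did not show is a separation beyond the scatter between a hydroxyalkyl tail and the aryl groups on that nitrogen, seen as an at least 2.4-fold lower number from compound 1 to compound 4 (0.39 log units; beyond the scatter) and as an at least 2.4-fold lower number from compound 2 to compound 4 (0.39 log units; beyond the scatter). Both steps are floors, not sizes, since each starts from a limit of the assay: the limit of > 100000 nM in this assay, at which 2 of the 4 values shown sit.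

The compounds shown leave open whether a longer chain than 6-hydroxyhexyl would move the read-out beyond the scatter. They also leave open whether the terminal hydroxy matters, which an amine or a carboxylic acid at the chain end would test.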